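Trimming a Methoxy Group from Compound 3

This account rests on a few compounds, and the source may have more. Where it says the series, first, only, none or still open, it means among the compounds named here.

Compound 3 `COc1ccc(-c2[nH]c3ccc(OC)cc3c2/C=C(\C#N)S(=O)(=O)c2ccccc2)cc1` gives 2100 nM in a functional assay on OVCAR-4 cells (Homo sapiens) for inhibition, read by sulforhodamine B assay, with a stated time of 48 h (a higher number here means a weaker inhibitor of growth, a lower number a stronger inhibitor of growth), the second highest of three numbers. Compound 1 `COc1ccc(-c2[nH]c3ccccc3c2/C=C(\C#N)S(=O)(=O)c2ccccc2)cc1` gives 578 nM, and compound 2 `COc1ccc2[nH]c(-c3ccccc3)c(C=C(C#N)C#N)c2c1` gives 5400 nM. Going by the values given here, the one measured single-change step, a 3.6-fold higher number from compound 1 to compound 3 (0.56 log units; beyond the scatter), shows that adding a methoxy on an aromatic carbon raised the number modestly.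

Compound 4 `COc1ccc2[nH]c(-c3ccccc3)c(/C=C(\C#N)S(=O)(=O)c3ccccc3)c2c1` differs from compound 3 by hydrogen in place of methoxy on an aromatic carbon, a hydrogen in place of methoxy on an aromatic carbon, para to a large group. Among the compounds with values here, since the only comparable step, a 3.6-fold higher number from compound 1 to compound 3 (0.56 log units; beyond the scatter), points the opposite way for the reverse change, though at a different position, a modest fall in the number is expected, a 1.8-fold lower number from compound 3 to compound 4 (0.24 log units; within the scatter). Compound 4 is therefore estimated at 1200 nM, within a range from 400 nM to 3600 nM.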

Compound 4, concentration for 50% growth inhibition: 8300 nM
Compound 4: the middle estimate sits 6.9-fold (0.84 log units) below what was measured; measured number outside the range, above it.
By their numbers in this assay, from the lowest: compound 1; then compound 3; then compounds 2 and 4 (each within the scatter of the next).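

Changing 4-methoxyphenyl to phenyl brings a 4.0-fold higher number from compound 3 to compound 4 (0.60 log units; beyond the scatter) in this assay and so removing this methoxy costs growth inhibition. The earlier step of a 3.6-fold higher number from compound 1 to compound 3 (0.56 log units; beyond the scatter) came from adding a methoxy at a different place, so in these compounds the same group goes with a higher number at one place and a lower number at the other. Nothing available explains this contrast. On these data alone, whether a hydroxyl, an ethoxy group or a chlorine atom at this place would serve as well as methoxy stays open.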